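Swapping bromo for methylsulfanyl on compound 2

The source may report more compounds than this note shows. Statements on the series, on what has been measured and on what is new or still open speak of the compounds shown alone.

Values so far in a functional assay on A498 cells (Homo sapiens) for cytotoxicity; on this read-out lower numbers stand for stronger inhibition of growth and higher numbers for weaker inhibition of growth
- compound 1 `COc1ccc(C2=C(c3ccc(SC)cc3)CC3CCCN3C2=O)cc1Br` gives 600 nM
- compound 2 `CSc1ccc(C2=C(c3ccc(Br)cc3)C(=O)N3CCCC3C2)cc1` gives 7000 nM

Compound 2 holds the higher number of the pair at 7000 nM and so stands at the weak end of what is known. Compound 3 `CSc1ccc(C2=C(c3ccc(SC)cc3)C(=O)N3CCCC3C2)cc1` differs from compound 2 by methylsulfanyl in place of bromo on an aromatic carbon. The change is methylsulfanyl in place of bromo on an aromatic carbon. Within the data shown here, one measured step bears on this: a 12-fold higher number from compound 1 to compound 2 (1.07 log units; beyond the scatter) is large and alters the same aryl group. Among the measured compounds shown here, that step shows this group can move the number in this assay but gives no direction for methylsulfanyl, which no measured compound carries there. A modest fall, near the scatter, is expected since compound 2 already sits high at 7000 nM and the data are thin. The expected step is a 2.3-fold lower number from compound 2 to compound 3 (0.37 log units; beyond the scatter) and its size remains uncertain. For compound 3 the estimate is 3000 nM with an expected range from 600 nM to 15000 nM on present data.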

Compound 3, concentration for 50% growth inhibition: 15000 nM
For compound 3 the middle estimate is 5.0-fold (0.70 log units) below the measured one; the measured number falls inside the stated range.
By their numbers in this assay, from the lowest: compound 1; then compound 2; then compound 3.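

In this assay, methylsulfanyl in place of bromo on an aromatic carbon, para to a large group, gives a 2.1-fold higher number from compound 2 to compound 3 (0.33 log units; beyond the scatter), so this position responds to the swap and, of these two groups, bromo holds the lower number. Replacing the 3-bromo-4-methoxyphenyl group with 4-(methylsulfanyl)phenyl gives a 25-fold higher number from compound 1 to compound 3 (1.40 log units; beyond the scatter), and with both 4-substituted aryl groups now measured in that place, neither approaches compound 1. No available evidence accounts for either step.

Going by these compounds, whether an amine, a carboxylic acid or a longer chain on this aromatic carbon would bring the number down remains open. Also open, on these data alone, is which part of the 3-bromo-4-methoxyphenyl group, the bromo or the methoxy, carries the lower number of compound 1.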